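The source may report more compounds than this note shows. Statements on the series, on what has been measured and on what is new or still open speak of the compounds shown alone.

Compound 1 `Cc1nnc(SCc2ccccc2)n1N1C(=O)c2ccccc2C1=O` stands on the numbers only as a limit. In a functional assay on PC-3M cells (Homo sapiens) for cytotoxicity, read by MTT assay, with a stated time of 48 h (a lower number here means a stronger inhibitor, a higher number a weaker inhibitor), compound 1 gives > 200000 nM, which is a limit of the assay and not a number. Compound 2 `CCOC(=O)CSc1nnc(C)n1N1C(=O)c2ccccc2C1=O` gives > 200000 nM in this assay, again a limit. Compound 3 `Cc1nnc(SCC(=O)c2ccccc2)n1N1C(=O)c2ccccc2C1=O` gives > 200000 nM in this assay, also a limit. The three measured steps, a step that the two limits leave unreadable from compound 1 to compound 2, a step that the two limits leave unreadable from compound 1 to compound 3 and a step that the two limits leave unreadable from compound 2 to compound 3, therefore cannot be read in size or direction, because of the limit of > 200000 nM in this assay, at which 3 of the 3 values shown sit.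

Compound 4 `CCc1nnc(SCc2ccccc2)n1N1C(=O)c2ccccc2C1=O` differs from compound 1 by methyl in place of hydrogen on a saturated chain carbon bound to an aromatic carbon. Among the measured compounds shown here, none of the measured steps touches that place; all of them alter the group on the sulfur, and all three leave the compounds at the limit. For the measured compounds named here, there is thus no measured step from which a direction or a size for the change to compound 4 in this assay can be taken, and nothing among the measured compounds points to a reading beyond the scatter.

The step from compound 1 to compound 4 in this assay is expected to be a number no higher from compound 1 to compound 4 (the limit leaves the size open), most likely again unreadable. Compound 4 is estimated at 200000 nM in this assay, with a range from 80000 nM to 500000 nM, and most probably the assay will again report only a limit.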

Compound 4, half-maximal inhibitory concentration: > 200000 nM
Compound 4: a limit, no number; the forecaster's own chance of this, stated with the estimate: 85%; the middle value lies on the limit itself.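

The step from compound 1 to compound 4 cannot be read in size or direction, and no other new step arises, because both compounds stand at the same limit of the assay: the limit of > 200000 nM in this assay, at which 4 of the 4 values shown sit.

The compounds shown leave open whether methyl in place of hydrogen, or any change of the group on the sulfur, alters activity in this assay at all.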